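Aryl for cycloheptyl on the ring nitrogen: expected inhibition

This account rests on a few compounds, and the source may have more. Where it says the series, first, only, none or still open, it means among the compounds named here.

Measured in an assay on CHO cells for displacement of a labelled ligand from adenosine receptor A3 (Homo sapiens), read by scintillation counting, with a stated time of 120 min, tested at 10 uM; a lower number here means less inhibition, a higher number more inhibition at the concentration tested (going by the name of the read-out):
compound 1 `Nc1scc(CN2CCN(c3cccc(C(F)(F)F)c3)CC2)c1C(=O)c1ccc(Cl)cc1` gives 0%
compound 2 `Nc1scc(CN2CCN(c3ccc(Cl)c(C(F)(F)F)c3)CC2)c1C(=O)c1ccc(Cl)cc1` gives 3%
compound 3 `Nc1scc(CN2CCN(C3CCCCCC3)CC2)c1C(=O)c1ccc(Cl)cc1` gives 0%

Compound 3 stands level with compound 1, the two together the lowest of the three numbers; the step of a number 3 percentage points lower from compound 2 to compound 3 (within the scatter) is within the scatter, so no ordering among the three is supported.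

Compound 4 `Nc1scc(CN2CCN(c3ccc(F)c(F)c3)CC2)c1C(=O)c1ccc(Cl)cc1` differs from compound 3 by 3,4-difluorophenyl in place of cycloheptyl on an amine nitrogen in a ring. For the measured compounds named here, the steps that bear on this exchange are no change at the digits printed from compound 1 to compound 3 (within the scatter) and a number 3 percentage points lower from compound 2 to compound 3 (within the scatter): in both, an aryl group on the same ring nitrogen is traded against cycloheptyl with no movement beyond the scatter. The reverse trade in compound 4 is therefore expected to give a number 2 percentage points higher from compound 3 to compound 4 (within the scatter), no step beyond the scatter. Compound 4 is estimated at 2%, within -5% to 10%.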

Compound 4, a percentage reported as inhibition, at one concentration (the size of the read-out at that concentration, not a potency): 1%
Beside the measured number, compound 4's estimate is 1 percentage points above it, and the stated range covers the measured number.
By their numbers in this assay, from the lowest: compounds 1, 3, 4 and 2 (each within the scatter of the next).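

In this assay the exchange for 3,4-difluorophenyl gives a number 1 percentage points higher from compound 3 to compound 4 (within the scatter) while the comparisons with the other aryl groups give a number 2 percentage points lower from compound 2 to compound 4 (within the scatter) and a number 1 percentage points higher from compound 1 to compound 4 (within the scatter) in this series. On the amine nitrogen in a ring, a fluorine-only substituted phenyl now sits with the trifluoromethyl-bearing phenyl groups and cycloheptyl, and no ordering among the four is supported. Nothing available explains this absence of separation.

Open, from the compounds shown here alone, is whether an amine or a carboxylic acid on a longer chain at this nitrogen would give a step beyond the scatter. Changes elsewhere on the shared core also remain open.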